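The source may report more compounds than this note shows. Statements on the series, on what has been measured and on what is new or still open speak of the compounds shown alone.

Compound 1: `Cc1nc(-c2ccc(F)cc2)c(C(=O)N2CCN(c3ccc(C(=O)C(C)C)cc3)CC2)o1` — "not active" (no number reported)
Compound 2: `Cc1nc(-c2ccccc2)c(C(=O)N2CCN(c3cccc(C(N)=O)c3)CC2)o1` — 71 nM
Compound 3: `COc1cccc(N2CCN(C(=O)c3oc(C)nc3-c3ccc(F)cc3)CC2)c1` — 112 nM

In a functional assay on HL-60 cells (Homo sapiens) for inhibition, read by MTT assay, with a stated time of 72 h (a lower number here means a stronger inhibitor, a higher number a weaker inhibitor), compound 2 gives 71 nM, the lowest of the two numbers reported, yet compound 3 lies within the usual scatter of it, so the two cannot be ranked. Compound 1 is recorded in this assay without a number.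

Compound 4, `CC(=O)Nc1cccc(N2CCN(C(=O)c3oc(C)nc3-c3ccccc3)CC2)c1`, has not yet been measured. It differs from compound 2 in one place: acetamido in place of carbamoyl on an aromatic carbon. Both groups are small and uncharged, and alike in what is counted. Going by the values given here, no measured pair shows this change, so its size is unknown from the data; a small step is expected, most likely none beyond the scatter, with a slight weakening possible. Compound 4 is expected to give 120 nM in this assay, within 40 nM to 400 nM. The estimated step of a 1.7-fold higher number from compound 2 to compound 4 (0.23 log units; within the scatter) is expected to stay within the scatter.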

Compound 4, half-maximal inhibitory concentration: 329 nM
The estimate for compound 4 lay 2.7-fold (0.44 log units) below the measured number, and the stated range covers the measured number.
By their numbers in this assay, from the lowest: compounds 2 and 3 (each within the scatter of the next); then compound 4.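

In this assay putting acetamido in place of carbamoyl on this aromatic carbon gives a 4.6-fold higher number from compound 2 to compound 4 (0.67 log units; beyond the scatter) and this is a modest step. The two groups match in hydrogen-bond donors, hydrogen-bond acceptors and charge, yet this position still tells them apart. Nothing measured here accounts for the step. As far as these compounds go, whether an amine or a carboxylic acid at this place would give a number nearer that of compound 2 or of compound 4 remains open. So does whether a longer chain than acetamido would raise the number further.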